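Aryl group re-entering at the amine nitrogen of compound 3

A few compounds are considered here, and "the series" means these few. Any claim that something is new, unique, unknown or untested is made for them only; others in the source may bear on it.

Three compounds of the shared core have numbers in a functional assay on HeLa cells (Homo sapiens) for inhibition, read by MTT assay, with a stated time of 48 h; a lower number here means a stronger inhibitor, a higher number a weaker inhibitor. Compound 1 `CCOC(=O)C1=C(N/C=N/c2cccnc2Cl)Nc2[nH]nc(C)c2C1c1ccc(N(C)C)cc1` gives 4630 nM; compound 2 `CCOC(=O)C1=C(N/C=N/c2ccc([N+](=O)[O-])cc2)Nc2[nH]nc(C)c2C1c1ccc(N(C)C)cc1` gives 57800 nM; compound 3 `CCOC(=O)C1=C(NN=C(C#N)C#N)Nc2[nH]nc(C)c2C1c1ccc(N(C)C)cc1` gives 15200 nM. Compound 3 therefore stands second highest of the three: its nearest neighbour is compound 1, with a 3.3-fold higher number from compound 1 to compound 3 (0.52 log units; beyond the scatter) between them, while compound 2 lies further off, with a 3.8-fold lower number from compound 2 to compound 3 (0.58 log units; beyond the scatter).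

Compound 4 `CCOC(=O)C1=C(N/N=C(/C(=O)Br)c2ccc(Cl)cc2)Nc2[nH]nc(C)c2C1c1ccc(N(C)C)cc1` differs from compound 3 in one place: a group of 12 heavy atoms (8 carbon, 1 nitrogen, 1 oxygen, 1 chlorine, 1 bromine; one six-membered aromatic ring of carbon only) in place of a group of 6 heavy atoms (3 carbon, 3 nitrogen; no ring), on an amine nitrogen. The two steps that bear on this are the ones in which a group holding a six-membered aromatic ring was exchanged for the six-atom group without a ring, namely a 3.3-fold higher number from compound 1 to compound 3 (0.52 log units; beyond the scatter) and a 3.8-fold lower number from compound 2 to compound 3 (0.58 log units; beyond the scatter). Those steps were modest and ran in opposite directions, so the return of a six-membered aromatic ring of carbon only, here carrying a chlorine as the ring of compound 1 does, is expected to move the number only modestly, with the direction uncertain. For compound 4 the step is estimated at a 1.7-fold lower number from compound 3 to compound 4 (0.23 log units; within the scatter). Compound 4 is therefore estimated at 9000 nM, with a range from 2500 nM to 35000 nM.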

Compound 4, half-maximal inhibitory concentration: 49300 nM
The estimate for compound 4 lay 5.5-fold (0.74 log units) below the measured number; the whole stated range lies below it.
By their numbers in this assay, from the lowest: compound 1; then compound 3; then compounds 4 and 2 (each within the scatter of the next).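

Notes on the amine nitrogen, in this assay: a six-membered aromatic ring of carbon only does not by itself bring the number back towards compound 1 (an 11-fold higher number from compound 1 to compound 4 (1.03 log units; beyond the scatter)), and the group in compound 4 also compares unfavourably with the group without a ring (a 3.2-fold higher number from compound 3 to compound 4 (0.51 log units; beyond the scatter)). The groups of compound 2 and compound 4 share that ring type yet differ in their other atoms, and their numbers stay within the scatter of each other (a 1.2-fold lower number from compound 2 to compound 4 (0.07 log units; within the scatter)); compound 1, with its ring holding one hetero atom, goes against any link between a ring and a higher number than compound 3. No measured evidence on the cause of these steps is at hand.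

From the compounds shown here alone, the separate contributions of the chlorine and the carbonyl bromide in compound 4 remain open. Also open, going by these compounds, is how a carboxylic acid in place of the carbonyl bromide, or an unsubstituted phenyl ring, would read here.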